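Swapping the terminal piperazine for a propylpiperidine

A few compounds are considered here, and "the series" means these few. Any claim that something is new, unique, unknown or untested is made for them only; others in the source may bear on it.

Compound 2 `CC(C)S(=O)(=O)N1CCN(S(=O)(=O)CCCN2CCC(CNC(=O)c3cccc4c3OCCO4)CC2)CC1` and compound 1 `CCN1CCN(S(=O)(=O)CCCN2CCC(CNC(=O)c3cccc4c3OCCO4)CC2)CC1` share one core and differ only at the far end of the chain. Among the measured compounds shown here, in an assay on isolated protein for inhibition of 5-hydroxytryptamine receptor 4 (Homo sapiens) (a lower number here means a stronger inhibitor, a higher number a weaker inhibitor), compound 1 gives 0.0501 nM, and compound 2 gives 0.126 nM, so compound 2 stands at the higher of the two numbers, with compound 1 its only neighbour. The step of a 2.5-fold higher number from compound 1 to compound 2 (0.40 log units; beyond the scatter) shows that a change at that terminal ring shifts the number modestly. Compound 3 `CCCC1CCN(S(=O)(=O)CCCN2CCC(CNC(=O)c3cccc4c3OCCO4)CC2)CC1` goes further: 4-propylpiperidin-1-yl in place of 4-(isopropylsulfonyl)piperazin-1-yl on a sulfonyl sulfur. For the measured compounds named here, no measured step covers the loss of the second ring nitrogen together with its isopropylsulfonyl group, so the one step seen only hints that the terminal ring tolerates change. The number for compound 3 is therefore expected to stay close to that of compound 2, with a step of a 1.3-fold lower number from compound 2 to compound 3 (0.10 log units; within the scatter) and a wide range. The estimate for compound 3 is 0.1 nM, between 0.025 nM and 0.4 nM.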

Compound 3, inhibition constant: 0.0631 nM
Compound 3: middle estimate off by 1.6-fold (0.20 log units), on the high side; the range from low to high includes it.
By their numbers in this assay, from the lowest: compounds 1, 3 and 2 (each within the scatter of the next, the first and the last beyond it).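

In this assay the group on the sulfonyl sulfur tolerates a larger change than the earlier pair showed: the steps of a 2.0-fold lower number from compound 2 to compound 3 (0.30 log units; within the scatter) and a 1.3-fold higher number from compound 1 to compound 3 (0.10 log units; within the scatter) both replace a piperazine with 4-propylpiperidin-1-yl, which has one ring hetero atom and no hydrogen-bond acceptors. Among these three compounds, neither the second ring nitrogen nor the isopropylsulfonyl group is needed for a sub-nanomolar number, since compound 3 gives 0.0631 nM without either. No measurement shown gives a reason for this tolerance. 

The compounds shown leave open whether any terminal ring is needed on the sulfonyl sulfur, as an open-chain dialkylamine could test. They also leave open how a carboxylic acid or a primary amine on the terminal ring would read.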